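Fluoro for trifluoromethoxy: a metabolic stability step forecast

The source may hold more compounds than are shown below. What is called first, only, known or untested is meant among the compounds shown, and "the series" means these compounds.

Of the compounds shown here, two have been measured so far in an ADME assay on cells (Hepatocyte, Rattus norvegicus) for metabolic stability; a higher number here means faster removal of the compound, a lower number slower removal. Compound 1 `O=C(O)CCC(=O)N(C1CC1)[C@H]1c2ccccc2N(C(=O)c2cccc(OC(F)(F)F)c2)[C@H]2CC[C@H]21` gives 15 uL/min, and compound 2 `O=C(O)CCC(=O)N(C1CC1)[C@H]1c2ccccc2N(C(=O)c2ccc(OC(F)(F)F)cc2)[C@H]2CC[C@H]21` gives 13 uL/min. These two numbers lie within the usual scatter of each other, as the step of a 1.2-fold lower number from compound 1 to compound 2 (0.06 log units; within the scatter) shows, so neither compound can be said to be cleared faster or slower than the other.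

Compound 3 `O=C(O)CCC(=O)N(C1CC1)[C@H]1c2ccccc2N(C(=O)c2ccc(F)cc2)[C@H]2CC[C@H]21` is not yet measured. It differs from compound 2 by fluoro in place of trifluoromethoxy on an aromatic carbon. Going by the values given here, no measured step bears on this change: the only step available, a 1.2-fold lower number from compound 1 to compound 2 (0.06 log units; within the scatter), moves the trifluoromethoxy group from one position to another and does not remove it. The account therefore rests on compound 2 alone, whose value 13 uL/min is the nearest reference.

In this assay, compound 3 is expected to give about 12 uL/min, with a range from 5 uL/min to 28 uL/min. The expected step of a 1.1-fold lower number from compound 2 to compound 3 (0.03 log units; within the scatter) is estimated to fall within the scatter.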

Compound 3, intrinsic clearance in a liver preparation (reported as CLH), per the amount of preparation that the assay uses: 14 uL/min
Beside the measured number, compound 3's estimate is 1.2-fold (0.07 log units) below it, and the stated range covers the measured number.
By their numbers in this assay, from the lowest: compounds 2, 3 and 1 (each within the scatter of the next).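

In this assay, the step of a 1.1-fold higher number from compound 2 to compound 3 (0.03 log units; within the scatter) shows that fluoro can stand in place of trifluoromethoxy on this aromatic carbon, para to a large group, without a difference that can be read, although fluoro carries fewer heavy atoms. The step of a 1.1-fold lower number from compound 1 to compound 3 (0.03 log units; within the scatter) also lies within the scatter, so 4-fluorophenyl and 3-(trifluoromethoxy)phenyl on the carbonyl carbon cannot be told apart in this read-out either. Nothing available accounts for this lack of a readable difference.

The compounds shown leave open whether a group of another kind on this aromatic carbon, such as an amine or a nitrile, would also stay within the scatter of compound 2. They also leave open how a plain phenyl, with no group on that carbon, would compare.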